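Swapping Chloro for Fluoro on the Pyrimidine-Bearing Core

This account rests on a few compounds, and the source may have more. Where it says the series, first, only, none or still open, it means among the compounds named here.

Measured compounds:
compound 1, `COc1cc(F)ccc1-c1nc(Nc2ccc3c(N4CCCNCC4)c(C(C)=O)c(=O)oc3c2)ncc1F`, 420 nM
compound 2, `COc1cc(F)ccc1-c1nc(Nc2ccc3c(N4CCN(C)CC4)c(C(C)=O)c(=O)oc3c2)ncc1Cl`, 1390 nM

For the measured compounds named here, in a functional assay on MV4-11 cells (Homo sapiens) for inhibition, read by luminescence and CellTiter-Glo, with a stated time of 72 h (a higher number here means a weaker inhibitor, a lower number a stronger inhibitor), compound 2 gives 1390 nM, the highest of the two numbers; the only other measured compound, compound 1, gives 420 nM, which lies beyond the usual scatter of this assay. Going by the values given here, compound 1 and compound 2 differ in two places at once, so no single step between them can be read off.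

Compound 3 is `COc1cc(F)ccc1-c1nc(Nc2ccc3c(N4CCN(C)CC4)c(C(C)=O)c(=O)oc3c2)ncc1F`. It differs from compound 2 in one place: fluoro in place of chloro on an aromatic carbon.

Nothing measured here isolates the effect of this exchange, since compound 1 carries the fluoro but also a different ring on the shared core. A small step in this assay is expected, probably toward a lower number, and it may not exceed the scatter. For compound 3 the estimated value is 900 nM, with a range of 350 nM to 2300 nM, meaning an expected step of a 1.5-fold lower number from compound 2 to compound 3 (0.19 log units; within the scatter).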

Compound 3, half-maximal inhibitory concentration: 400 nM
Compound 3: middle estimate off by 2.3-fold (0.35 log units), on the high side; low and high end bracket the measured number.
By their numbers in this assay, from the lowest: compounds 3 and 1 (each within the scatter of the next); then compound 2.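

In this assay, the exchange at this aromatic carbon, ortho to a 4-fluoro-2-methoxyphenyl group, can now be read on its own: fluoro in place of chloro gives a 3.5-fold lower number from compound 2 to compound 3 (0.54 log units; beyond the scatter). A change of one atom here therefore moves the number clearly, while 4-methylpiperazin-1-yl in place of 1,4-diazepan-1-yl, with fluoro on this carbon, gives a 1.1-fold lower number from compound 1 to compound 3 (0.02 log units; within the scatter), so that ring exchange cannot be told apart from repeat-measurement noise in this pair. Nothing measured here bears on the cause of the fluoro and chloro difference.

The compounds shown leave open how hydrogen, a methyl group or a nitrile on this carbon would compare with fluoro and chloro. They also leave open whether 1,4-diazepan-1-yl and 4-methylpiperazin-1-yl would remain this close with chloro in place of fluoro.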